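Furan-2-yl in place of 4-aminophenyl in the series

The compounds below may be only part of what the source reports. "The series", "measured", "known", "first", "only" and "open" are said of these compounds alone.

In a functional assay on NCI-H460 cells (Homo sapiens) for antiproliferative activity, read by MTT assay, with a stated time of 48 h (on this read-out lower numbers stand for stronger inhibition and higher numbers for weaker inhibition), compound 1 `COc1cc(-c2cccc3nc(-c4ccccc4)oc23)cc(OC)c1OC` gives 6800 nM, compound 2 `COc1cc(-c2cccc3nc(-c4cccc(O)c4)oc23)cc(OC)c1OC` gives 1900 nM and compound 3 `COc1cc(-c2cccc3nc(-c4ccc(N)cc4)oc23)cc(OC)c1OC` gives 310 nM, the lowest of the three numbers.

Compound 4 `COc1cc(-c2cccc3nc(-c4ccco4)oc23)cc(OC)c1OC` has furan-2-yl in place of 4-aminophenyl, on an aromatic carbon of a five-membered aromatic ring with 1 nitrogen and 1 oxygen: furan-2-yl in place of 4-aminophenyl on an aromatic carbon.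

Going by the values given here, three measured steps bear on this change. Adding amino gave a large step, a 22-fold lower number from compound 1 to compound 3 (1.34 log units; beyond the scatter). Adding hydroxy gave a modest one, a 3.6-fold lower number from compound 1 to compound 2 (0.55 log units; beyond the scatter), and the exchange of aryl groups gave another modest one, a 6.1-fold lower number from compound 2 to compound 3 (0.79 log units; beyond the scatter). Compound 4 has no amino group, so most of the gain seen for compound 3 is expected to be lost. Among the compounds with values here, no measured compound carries furan-2-yl, which leaves the size uncertain.

A large step to a higher number is expected in this assay. The estimated step is a 9.7-fold higher number from compound 3 to compound 4 (0.99 log units; beyond the scatter). Compound 4 is estimated at 3000 nM, with an expected range from 900 nM to 12000 nM.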

Compound 4, half-maximal inhibitory concentration: 2600 nM
The estimate for compound 4 lay 1.2-fold (0.06 log units) above the measured number; low and high end bracket the measured number.
By their numbers in this assay, from the lowest: compound 3; then compounds 2 and 4 (each within the scatter of the next); then compound 1.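

The earlier gains at this position came with an added amino or hydroxy group, but furan-2-yl carries neither and still improves on phenyl in this assay (a 2.6-fold lower number from compound 1 to compound 4 (0.42 log units; beyond the scatter)). A gain here therefore does not depend on either of those groups. Furan-2-yl cannot be separated from 3-hydroxyphenyl (a 1.4-fold higher number from compound 2 to compound 4 (0.14 log units; within the scatter)), whereas 4-aminophenyl stays clearly ahead of furan-2-yl (an 8.4-fold higher number from compound 3 to compound 4 (0.92 log units; beyond the scatter)) and is the only group of the four whose steps to all the others lie beyond the scatter.

Nothing available accounts for these differences between the groups. On these data alone, it remains open whether the gain from 4-aminophenyl would carry over to furan-2-yl bearing an amino group, or to a phenyl ring bearing a methylamino or acetamido group instead.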